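Moving the Nitrile on the Cyanophenyl Group

The compounds below may be only part of what the source reports. "The series", "measured", "known", "first", "only" and "open" are said of these compounds alone.

Going by the values given here, in a functional assay on MCF7 cells (Homo sapiens) for antiproliferative activity, read by MTT assay, with a stated time of 72 h (on this read-out higher numbers stand for weaker inhibition and lower numbers for stronger inhibition), compound 1 (`COc1cc2c(Nc3ccc(C#N)cc3)ncnc2cc1OCCCN1CCCC1`) gives 16200 nM, the only exact number available so far. Compound 2 (`COc1cc2c(Nc3ccc(C#N)cc3)ncnc2cc1OCCCN1CCc2ccccc2C1`) gives > 100000 nM, which is a limit of the assay and not a number. Compound 3 (`COc1cc2c(Nc3cccc(C#N)c3)ncnc2cc1OCCCN1CCCC1`) keeps the pyrrolidin-1-yl group of compound 1 and differs elsewhere: 3-cyanophenyl in place of 4-cyanophenyl on a nitrogen on an aromatic ring. In words, it has 3-cyanophenyl in place of 4-cyanophenyl on a nitrogen on an aromatic ring. Among the compounds with values here, the only measured step, an at least 6.1-fold higher number from compound 1 to compound 2 (0.79 log units; beyond the scatter), replaces the pyrrolidin-1-yl group, so it says little about this change. Within the data shown here, no step at this nitrogen has been measured. With no measured guide, the expected change in this assay stays within the scatter, an estimated 1.1-fold higher number from compound 1 to compound 3 (0.05 log units; within the scatter). The estimate for compound 3 is 18000 nM, with an expected range of 6000 nM to 55000 nM.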

Compound 3, half-maximal inhibitory concentration: 33900 nM
Compound 3: middle estimate off by 1.9-fold (0.27 log units), on the low side; the range from low to high includes it.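

In this assay, going by these compounds alone, the earlier step changed only the far end of the chain, while this one reads the aryl group on the nitrogen for the first time: the atoms stay the same, and 3-cyanophenyl in place of 4-cyanophenyl gives a 2.1-fold higher number from compound 1 to compound 3 (0.32 log units; beyond the scatter). So where the nitrile sits on this phenyl ring does register in the read-out, modestly but beyond the usual scatter, and of this pair compound 1 is the stronger inhibitor. Nothing available here accounts for that difference.

The two compounds compared leave open whether the nitrile itself matters, a question that a plain phenyl group, or a phenyl ring carrying an amine or a carboxylic acid in its place, would address. Also open, going by these compounds, is whether the preference for 4-cyanophenyl holds with 1,2,3,4-tetrahydroisoquinolin-2-yl on the chain.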